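Capping the primary amine of compound 1 with methoxycarbonyl

The source may hold more compounds than are shown below. What is called first, only, known or untested is meant among the compounds shown, and "the series" means these compounds.

Compound 1 `NC[C@@H]1CCCc2cc(S(=O)(=O)c3cccc(F)c3)ccc21` holds the lowest number of the three in an assay on isolated protein for displacement of a labelled ligand from 5-hydroxytryptamine receptor 6 (Homo sapiens) (on this read-out lower numbers stand for stronger inhibition and higher numbers for weaker inhibition), where compound 1 gives 0.0794 nM. In this assay compound 3 `CN(CC(N)=O)C[C@@H]1CCCc2cc(S(=O)(=O)c3cccc(F)c3)ccc21` gives 1.26 nM, and compound 2 `O=C1CN(C[C@@H]2CCCc3cc(S(=O)(=O)c4cccc(F)c4)ccc32)CCN1` gives 6.31 nM. The step of a 16-fold higher number from compound 1 to compound 3 (1.20 log units; beyond the scatter) and the step of a 79-fold higher number from compound 1 to compound 2 (1.90 log units; beyond the scatter) both lie beyond the scatter, and the pair is separated by a 5.0-fold lower number from compound 2 to compound 3 (0.70 log units; beyond the scatter). Every measured change so far has been made at the same amine, and each one has raised the number in this assay.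

Compound 4 `COC(=O)NC[C@@H]1CCCc2cc(S(=O)(=O)c3cccc(F)c3)ccc21` differs from compound 1 by methoxycarbonyl in place of hydrogen on an amine nitrogen. The two measured steps away from compound 1 bear on it directly, since they too alter this amine, and both were large. For compound 4 a rise beyond the scatter in this assay is therefore expected, with the step estimated as a 38-fold higher number from compound 1 to compound 4 (1.58 log units; beyond the scatter). Neither measured step carries the same group, so the size is taken as lying near the two known steps. Compound 4 is expected to give 3 nM in this assay, with a range from 0.4 nM to 25 nM.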

Compound 4, inhibition constant: 1.59 nM
The estimate for compound 4 lay 1.9-fold (0.28 log units) above the measured number, and the stated range covers the measured number.
By their numbers in this assay, from the lowest: compound 1; then compounds 3 and 4 (each within the scatter of the next); then compound 2.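

In this assay the rise at this amine also appears with a single methoxycarbonyl on the nitrogen, as a 20-fold higher number from compound 1 to compound 4 (1.30 log units; beyond the scatter) shows, so all three changes measured here raise the number relative to compound 1. The step of a 1.3-fold higher number from compound 3 to compound 4 (0.10 log units; within the scatter) leaves (methoxycarbonyl)amino and (carbamoylmethyl)(methyl)amino unresolved in this read-out, while the step of a 4.0-fold lower number from compound 2 to compound 4 (0.60 log units; beyond the scatter) keeps (methoxycarbonyl)amino apart from 3-oxopiperazin-1-yl. No measured evidence bears on what lies behind these differences.

The compounds shown leave open whether a single methyl or an acetyl group on this amine nitrogen would stay closer to compound 1 than methoxycarbonyl does. Also open, from the compounds shown here alone, is how a longer chain in place of the aminomethyl would read out with the rest of compound 1 unchanged.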